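Removing the Isopropoxycarbonyl Group: A Permeability Estimate

A few compounds are considered here, and "the series" means these few. Any claim that something is new, unique, unknown or untested is made for them only; others in the source may bear on it.

Measured compounds:
Compound 1, `CC(C)NCCS(=O)(=O)NC(=O)c1ccc(Nc2nc(NC3(c4ccc(Cl)cc4)CC3)nc(OCC(F)(F)F)n2)cc1`, 45 nm/s
Compound 2, `CC(C)OC(=O)NCCS(=O)(=O)NC(=O)c1ccc(Nc2nc(NC3(c4ccc(Cl)cc4)CC3)nc(OCC(F)(F)F)n2)cc1`, 71 nm/s

Both numbers come from a physicochemical assay for permeability, using PAMPA, at pH 7.4; a higher number here means that the compound crosses the layer faster, a lower number that the compound crosses the layer more slowly. Compound 2 stands highest of the two in this assay, with compound 1 nearest at 45 nm/s, but a 1.6-fold higher number from compound 1 to compound 2 (0.20 log units; within the scatter), so the two are not distinguishable here.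

Compound 3, `NCCS(=O)(=O)NC(=O)c1ccc(Nc2nc(NC3(c4ccc(Cl)cc4)CC3)nc(OCC(F)(F)F)n2)cc1`, has not been measured. Its change from compound 2 is hydrogen in place of isopropoxycarbonyl on an amine nitrogen. Among the compounds with values here, the only measured step, a 1.6-fold higher number from compound 1 to compound 2 (0.20 log units; within the scatter), swapped one group on that nitrogen for another; neither measured compound carries a hydrogen there, so no step directly matches this change. With that step inside the scatter, the data give no firm direction, and the estimate leans only modestly downward with a wide range.

Compound 3 is expected to give about 30 nm/s in this assay, most likely between 8 nm/s and 80 nm/s, a step of a 2.4-fold lower number from compound 2 to compound 3 (0.37 log units; beyond the scatter).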

Compound 3, apparent permeability: 153 nm/s
For compound 3 the middle estimate is 5.1-fold (0.71 log units) below the measured one; the measured number lies above the stated range.
By their numbers in this assay, from the lowest: compounds 1 and 2 (each within the scatter of the next); then compound 3.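

In this assay, hydrogen in place of isopropoxycarbonyl on the amine nitrogen gives a 2.2-fold higher number from compound 2 to compound 3 (0.33 log units; beyond the scatter) and hydrogen in place of isopropyl gives a 3.4-fold higher number from compound 1 to compound 3 (0.53 log units; beyond the scatter) on the same nitrogen. The swap between the two groups had stayed within the scatter, so only now does this nitrogen appear as a place where a change can move the number beyond it, with the free amine above both substituted compounds. No measurement shown gives a reason for this rise.

As far as these compounds go, it remains open whether a small group such as methyl or acetyl on this nitrogen would stay close to compound 3 or fall back towards compound 1 and compound 2. Equally open, from the compounds shown here alone, is how a hydroxyl group in place of the amine, or a longer chain, would compare in this assay with compound 3.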